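Replacing the 3-carboxyazetidin-1-yl group of compound 3

The compounds below may be only part of what the source reports. "The series", "measured", "known", "first", "only" and "open" are said of these compounds alone.

compound 1 `O=S(=O)(c1cccc(C(F)(F)F)c1)N1CCc2ccc(-c3cc(F)cc(OC(F)F)c3)cc21`: 0.19 h
compound 2 `O=C(O)CCCC1Cc2ccc(-c3cc(F)cc(OC(F)F)c3)cc2N1S(=O)(=O)c1cccc(C(F)(F)F)c1`: 1.56 h
compound 3 `O=C(O)C1CN(C(=O)CC2Cc3ccc(-c4cc(F)cc(OC(F)F)c4)cc3N2S(=O)(=O)c2cccc(C(F)(F)F)c2)C1`: 1.1 h

Compound 3 belongs to the upper pair of these three in an ADME assay on microsomes from liver (Mus musculus) for metabolic stability, read by LC-MS, using NADPH, with a stated time of 60 min, tested at 1 uM; a lower number here means that the compound disappears faster, a higher number that the compound lasts longer. Within the data shown here, there is a 1.4-fold lower number from compound 2 to compound 3 (0.15 log units; within the scatter), and the single low value gives a 5.8-fold higher number from compound 1 to compound 3 (0.76 log units; beyond the scatter).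

Compound 4 `O=C(CC1Cc2ccc(-c3cc(F)cc(OC(F)F)c3)cc2N1S(=O)(=O)c1cccc(C(F)(F)F)c1)N1CC2(COC2)C1` differs from compound 3 in one place, on a carbonyl carbon: a group of 7 heavy atoms (5 carbon, 1 nitrogen, 1 oxygen; 2 four-membered non-aromatic rings with 1 hetero atom each) in place of a group of 7 heavy atoms (4 carbon, 1 nitrogen, 2 oxygen; one four-membered non-aromatic ring with 1 hetero atom), on a carbonyl carbon. The 3-carboxyazetidin-1-yl group leaves, and its carboxy group goes with it.

Among the measured compounds shown here, no measured step makes this exact swap. The closest evidence is an 8.2-fold higher number from compound 1 to compound 2 (0.91 log units; beyond the scatter), together with the step to compound 3 above. Both of these add a side chain that carries a carboxy group, so the data cannot separate the chain from the carboxy group. Compound 1, which has neither, gives 0.19 h. Compound 4 keeps a chain but has no carboxy group, so it is expected to land part of the way down.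

A modest fall is expected, with a 2.2-fold lower number from compound 3 to compound 4 (0.34 log units; beyond the scatter) as the estimate. For compound 4 the estimated half-life is 0.5 h, with an expected range of 0.2 h to 1.2 h.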

Compound 4, half-life: 0.0117 h
Compound 4: middle estimate off by 43-fold (1.63 log units), on the high side; measured number below the stated range.
By their numbers in this assay, from the lowest: compound 4; then compound 1; then compounds 3 and 2 (each within the scatter of the next).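

In this assay, the side chain alone does not account for the longer half-lives of the earlier compounds: the swap on the carbonyl carbon gives a 94-fold lower number from compound 3 to compound 4 (1.97 log units; beyond the scatter), and the comparison with the carboxy-bearing chain gives a 130-fold lower number from compound 2 to compound 4 (2.12 log units; beyond the scatter). Nor does the result simply return to the level of the unsubstituted core, as adding the whole group at the saturated ring carbon gives a 16-fold lower number from compound 1 to compound 4 (1.21 log units; beyond the scatter), so among these compounds a side chain with a carboxy group lengthens the half-life and the one without shortens it. No measurement shown here explains this sharp fall.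

Compound 4 both loses the carboxy group and gains a second four-membered ring, so the contribution of each change remains unresolved. A plain azetidin-1-yl group on the same carbonyl carbon would be informative, as it lacks both the carboxy group and the oxygen-containing ring.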